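The compounds below may be only part of what the source reports. "The series", "measured", "known", "first", "only" and "open" are said of these compounds alone.

Compound 1, with the structure `NC[C@@H]1NC[C@H](O)[C@H](O)[C@H]1O`, is a small ring carrying three hydroxyl groups and an aminomethyl arm. In an assay on isolated protein for inhibition of alpha-galactosidase (Coffea arabica), read by spectrophotometry, tested at 100 uM (on this read-out lower numbers stand for less inhibition and higher numbers for more inhibition at the one concentration tested (going by the name of the read-out)), compound 1 gives 13%, the lowest of the three numbers recorded here. The other two measured compounds carry larger groups on the aminomethyl arm. Compound 2, `O=C(CCCCC1CCCCC1)NC[C@H]1NC[C@H](O)[C@@H](O)[C@H]1O`, bears an amide chain ending in a cyclohexyl ring and gives 57% in this assay. Compound 3, `COc1ccc(OC)c(/C=C/C(=O)NC[C@H]2NC[C@H](O)[C@@H](O)[C@H]2O)c1`, bears an unsaturated amide linked to a dimethoxyphenyl ring and gives 57% in this assay. Both of these values sit well beyond the scatter above that of compound 1, while compound 2 and compound 3 cannot be told apart on these numbers.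

Compound 4, `NC[C@@H]1NC[C@H](O)[C@@H](O)[C@H]1O`, has not yet been measured in this assay. Its relation to compound 1 is the two compounds have the same atoms and bonds and differ only in configuration as drawn: 1 of 4 stereo elements differ; a stereocentre at a saturated ring carbon is drawn S in compound 1 and R in compound 4. Within the data shown here, no measured pair differing only in configuration is available, so the size of such a step in this assay is unknown. Given that compound 1 gives only 13%, the expectation for compound 4 is a small rise, with the step of a number 9 percentage points higher from compound 1 to compound 4 (within the scatter) estimated as modest and possibly within the scatter. The estimated value for compound 4 in this assay is 22%, expected to fall between 5% and 55%.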

Compound 4, a percentage reported as inhibition, at one concentration (the size of the read-out at that concentration, not a potency): 9%
Estimate against measurement, compound 4: 13 percentage points above; low and high end bracket the measured number.
By their numbers in this assay, from the lowest: compounds 4 and 1 (each within the scatter of the next); then compounds 2 and 3 (each within the scatter of the next).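

In this assay, inverting one stereocentre at a saturated ring carbon, from S to R as drawn, comes with a number 4 percentage points lower from compound 1 to compound 4 (within the scatter). Among these compounds, until now no pair in this set isolated configuration, so the size of such a step was unknown; here, with the aminomethyl arm left free, this single inversion produces no change that can be told from the ordinary spread of repeated measurements. The pair gives a clean reading of this one stereocentre, because nothing else in the structures varies: the fact that compounds 1 and 4 differ only in the configuration as drawn

As far as these compounds go, what stays open is whether the same inversion would remain without visible effect once the aminomethyl arm carries an amide like those in compound 2 and compound 3, and whether inverting any of the other stereocentres of the core would behave the same way. Also open, from the compounds shown here alone, is what would happen at this position with a sulfonamide or a urea on the arm in place of the amide, since neither group appears in any compound here.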